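The source may hold more compounds than are shown below. What is called first, only, known or untested is meant among the compounds shown, and "the series" means these compounds.

This piece follows one step in an ADME assay on Vero cells (Chlorocebus sabaeus) for cytotoxicity, with a stated time of 7 days (on this read-out higher numbers stand for lower toxicity in this test and lower numbers for higher toxicity in this test), from compound 1 to a compound that has not yet been tested.

Compound 1, with the structure `COc1ccc2[nH]c(C(=O)N3CC(=O)N(Cc4ccccc4)[C@@H](CN4CCC(C)CC4)C3)cc2c1`, gives in this assay a result that is only a limit of the test and not a number: > 30000 nM. Compound 2, with the structure `COc1ccc2[nH]c(C(=O)N3CC(=O)N(Cc4ccccc4)[C@@H](CN4CCN(c5ccc(F)cc5)CC4)C3)cc2c1`, also reaches only a limit in this assay, reported as > 30000 nM. Among the compounds with values here, compound 1 therefore stands at the edge of what the test can report, and the same holds for the one other compound measured, as the evidence shows: the limit of > 30000 nM in this assay, at which 2 of the 2 values shown sit.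

Compound 3, with the structure `COc1ccc2[nH]c(C(=O)N3CC(=O)N(Cc4ccccc4)[C@@H](CN4CCC5(CCCC5)CC4)C3)cc2c1`, differs from compound 1 in a single place, described as a group of 10 heavy atoms (9 carbon, 1 nitrogen; one five-membered non-aromatic ring of carbon only, one six-membered non-aromatic ring with 1 hetero atom) in place of a group of 7 heavy atoms (6 carbon, 1 nitrogen; one six-membered non-aromatic ring with 1 hetero atom), on a saturated chain carbon bound to a saturated ring carbon.

Within the data shown here, no step between two measured compounds is known here, so the size of this change can only be anticipated. The step from compound 1 to compound 3 in this assay is expected to be a number no higher from compound 1 to compound 3 (the limit leaves the size open), that is, nothing beyond the usual scatter. Compound 3 is therefore estimated at 30000 nM, within a range from 15000 nM to 60000 nM, most likely again reported only as a limit.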

Compound 3, half-maximal cytotoxic concentration: 3600 nM
Estimate against measurement, compound 3: 8.3-fold (0.92 log units) above; the whole stated range lies above it.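

In this assay, replacing the 4-methylpiperidin-1-yl group with the group of 10 heavy atoms, which adds a five-membered ring of carbon only, gives an at least 8.3-fold lower number from compound 1 to compound 3 (0.92 log units; beyond the scatter), so what sits on this saturated chain carbon can clearly change the read-out. The earlier compounds shown here could not show this, since neither gave a number and the two different groups they carry here left the result at the edge of the test: the limit of > 30000 nM in this assay, at which 2 of the 3 values shown sit. Within the data shown here, compound 3 thus gives the first true number in this small set, while compound 1 has only a limit, so the step is a minimum and its full size remains unknown.

The compounds shown leave open whether the added carbon ring itself matters or whether other larger carbon groups would do the same, which a 4-propylpiperidin-1-yl group at this place could help to separate. They also leave open how this assay would respond to a carboxylic acid or a second amine on the same six-membered ring.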